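Replacing the Difluoropiperidine Amide: an Expectation for Compound 4

The source may report more compounds than this note shows. Statements on the series, on what has been measured and on what is new or still open speak of the compounds shown alone.

Measured so far:
compound 1 `CC(C(=O)N1CCC(F)(F)CC1)N1CCN(S(=O)(=O)c2ccc(C(C)(C)C)cc2)CC1` — > 40000 nM
compound 2 `CC(C(=O)N1CCc2ccccc2C1(C)C)N1CCN(S(=O)(=O)c2ccc(C(C)(C)C)cc2)CC1` — 31000 nM
compound 3 `CCC1(CC)c2ccccc2CCN1C(=O)C(C)N1CCN(S(=O)(=O)c2ccc(C(C)(C)C)cc2)CC1` — > 40000 nM

In an ADME assay on HepG2 cells (Homo sapiens) for inhibition, with a stated time of 48 h (a higher number here means that more compound is needed for the effect, a lower number that less compound is needed), compound 1 gives > 40000 nM, and this is a limit of the assay rather than a number. Compound 3 gives > 40000 nM in this assay, which is likewise a limit. Compound 2 gives 31000 nM in this assay. Compound 1 therefore stands at the limit of > 40000 nM in this assay, at which 2 of the 3 values shown sit, and its true value is not resolved beyond that.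

Compound 4 `CC(C(=O)N1CCc2cccnc2C1)N1CCN(S(=O)(=O)c2ccc(C(C)(C)C)cc2)CC1` differs from compound 1 in one place: a group of 10 heavy atoms (8 carbon, 2 nitrogen; one six-membered non-aromatic ring with 1 hetero atom, one six-membered aromatic ring with 1 hetero atom) in place of a group of 8 heavy atoms (5 carbon, 1 nitrogen, 2 fluorine; one six-membered non-aromatic ring with 1 hetero atom), on a carbonyl carbon.

Within the data shown here, no step between two measured compounds is available in this assay, so there is no measured precedent for the size of this change. Since compound 1 rests at a limit because of the limit of > 40000 nM in this assay, at which 2 of the 3 values shown sit, the expected step of a number no higher from compound 1 to compound 4 (the limit leaves the size open) is set at none beyond the scatter, with any shift more likely to stay within the unresolved region than to move the value into the measurable range. Compound 4 is accordingly expected to give 40000 nM, with a range from 18000 nM to 90000 nM, and it is considered likely that this assay again reports only a limit.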

Compound 4, half-maximal effective concentration: > 40000 nM
Compound 4: a limit, no number; the forecaster's own chance of this, stated with the estimate: 65%; the middle value lies on the limit itself.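

In this assay compound 4 gives > 40000 nM, which is a limit of the assay and not a number. Compound 1 also rests at a limit, so the size of the change between compound 1 and compound 4 cannot be read. The compounds shown leave open where the true values of these two compounds lie: the limit of > 40000 nM in this assay, at which 3 of the 4 values shown sit.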